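This account rests on a few compounds, and the source may have more. Where it says the series, first, only, none or still open, it means among the compounds named here.

Measured so far in a functional assay on HEK293 cells (Homo sapiens) for cytotoxicity (a higher number here means that more compound is tolerated, a lower number that less compound is tolerated), for the two compounds:

- compound 1 `COc1ccc([C@H]2CC(=O)N(c3cccc(N(C)C)c3)C2)cc1OC1CCCC1` gives > 10000 nM as a limit
- compound 2 `COc1ccc([C@H]2CC(=O)N(c3cccc(NS(=O)(=O)c4ccccc4F)c3)C2)cc1OC1CCCC1` gives > 10000 nM as a limit

Compound 2 stands only at a limit: it sits at the limit of > 10000 nM in this assay, at which 2 of the 2 values shown sit, and no number can be read from it. Compound 3 `COc1ccc([C@H]2CC(=O)N(c3cccc(NS(=O)(=O)c4ccccc4Br)c3)C2)cc1OC1CCCC1` changes one place of compound 2, given as bromo in place of fluoro on an aromatic carbon and described as bromo in place of fluoro on an aromatic carbon, ortho to a large group. Among the measured compounds shown here, the only measured step is a step that the two limits leave unreadable from compound 1 to compound 2 and it concerns another group, so its size offers no guide here. For the measured compounds named here, no measured step puts bromo in place of fluoro. In this assay no step beyond the scatter is therefore expected, and compound 3 will most likely return a limit again. The expected step is a step that the limit leaves unreadable from compound 2 to compound 3 on this reading. For compound 3 the estimated value is 12000 nM with an expected range from 6000 nM to 30000 nM in this estimate.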

Compound 3, half-maximal cytotoxic concentration: > 10000 nM
Compound 3: only a limit was reported; the forecaster's own chance of this, stated with the estimate: 85%; the middle value lies beyond the limit too.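

In this assay, among the compounds shown here, compound 3 gives > 10000 nM as a limit, so no step among compound 1, compound 2 and compound 3 can be read. The compounds shown leave open whether they differ at all in tolerated concentration, with every value at one limit: the limit of > 10000 nM in this assay, at which 3 of the 3 values shown sit.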